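This account rests on a few compounds, and the source may have more. Where it says the series, first, only, none or still open, it means among the compounds named here.

Measured so far:
Compound 1, `Nc1c(C=O)ncn1[C@@H]1O[C@H](COP(=O)(O)O)[C@@H](O)[C@H]1O`: 62000 nM
Compound 2, `O=[N+]([O-])c1cnn([C@@H]2O[C@H](COP(=O)(O)O)[C@@H](O)[C@H]2O)c1`: 22000 nM

Both compounds were tested in an assay on isolated protein for inhibition of multifunctional protein ADE2 (Gallus gallus); a lower number here means a stronger inhibitor, a higher number a weaker inhibitor. Among the compounds with values here, of the two numbers, compound 2 has the lower one; the only other compound, compound 1, sits a step higher that is beyond the usual scatter, so compound 2 is the stronger inhibitor of this pair.

The next compound builds on compound 2. Compound 3, `Nc1c([N+](=O)[O-])cnn1[C@@H]1O[C@H](COP(=O)(O)O)[C@@H](O)[C@H]1O`, keeps the whole shared core and differs in one place: amino in place of hydrogen on an aromatic carbon. Nothing else about the molecule changes.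

Within the data shown here, no pair of measured compounds shows this particular change, so there is no measured step to lean on. Compound 1 also carries an amino group on a five-membered aromatic ring and gives 62000 nM in this assay, but its ring and its other group differ from those of compound 3, so it offers only a loose hint. The step from compound 2 to compound 3 is expected to be a move toward a lower number, roughly a 5.5-fold lower number from compound 2 to compound 3 (0.74 log units; beyond the scatter), larger than the scatter. Compound 3 is therefore estimated at 4000 nM, with a likely range from 500 nM to 20000 nM.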

Compound 3, inhibition constant: 390 nM
Compound 3: the middle estimate sits 10-fold (1.01 log units) above what was measured; the whole stated range lies above it.
By their numbers in this assay, from the lowest: compound 3; then compound 2; then compound 1.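

In this assay, putting an amino group in place of hydrogen on this aromatic carbon, next to the ring nitrogen and next to the ring atom that bears a nitro group, gives a 56-fold lower number from compound 2 to compound 3 (1.75 log units; beyond the scatter). The earlier compounds shown here contained no pair that isolated this change, so the sensitivity of this position could not be read from them. Compound 3 now shows that this position matters greatly in this series: adding a single heavy atom, one nitrogen, while the rest of the molecule stays the same, produces a large step. Nothing measured here explains why the step is so large.

The compounds shown leave open whether the amino group itself is needed at this carbon, or whether a methyl, a hydroxyl or a methylamino group there would give a similarly low number. They also leave open whether a step of this size would remain with a nitrile or a carboxylic acid in place of the nitro group.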